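Sulfonyl in place of benzyl on the piperazine of compound 2

A few compounds are considered here, and "the series" means these few. Any claim that something is new, unique, unknown or untested is made for them only; others in the source may bear on it.

Compound 1 `COC(=O)c1ccc(C2SCC(=O)N2c2ccc(N3CCN(Cc4cccc(C)c4)CC3)cn2)c(OC)c1` gives 27300 nM in a functional assay on NALM-6 cells (Homo sapiens) for antiproliferative activity, read by MTT assay and trypan blue exclusion, with a stated time of 72 h; a lower number here means a stronger inhibitor, a higher number a weaker inhibitor.
Compound 2 `COC(=O)c1ccc(C2SCC(=O)N2c2ccc(N3CCN(Cc4ccc(Cl)c(Cl)c4)CC3)cn2)c(OC)c1` gives > 100000 nM in this assay, which is a limit.
Compound 3 `COC(=O)c1ccc(C2SCC(=O)N2c2ccc(N3CCN(S(=O)(=O)c4c(C)cc(C)cc4C)CC3)cn2)c(OC)c1` gives > 100000 nM in this assay, also a limit.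

Compound 2 stands at the limit, and so does compound 3, so only compound 1 has a number; both others sit at the limit of > 100000 nM in this assay, at which 2 of the 3 values shown sit. The change to compound 4 `COC(=O)c1ccc(C2SCC(=O)N2c2ccc(N3CCN(S(=O)(=O)c4ccc([N+](=O)[O-])cc4)CC3)cn2)c(OC)c1` is (4-nitrophenyl)sulfonyl in place of 3,4-dichlorobenzyl on an amine nitrogen in a ring. The step that bears on it most directly is the like-for-like swap of a benzyl for an arylsulfonyl, an at least 3.6-fold higher number from compound 1 to compound 3 (0.56 log units; beyond the scatter), which lowered activity. The step that the two limits leave unreadable from compound 2 to compound 3 cannot be read, since both ends are limits. The step of an at least 3.6-fold higher number from compound 1 to compound 2 (0.56 log units; beyond the scatter) shows that the dichlorobenzyl was already weaker than the methylbenzyl. Within the data shown here, with compound 2 already at the limit and the one readable benzyl-to-sulfonyl step pointing to weaker inhibition, compound 4 is expected to remain at or beyond the limit, a step that the limit leaves unreadable from compound 2 to compound 4. Compound 4 is therefore estimated at 150000 nM, with a range from 40000 nM to 600000 nM.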

Compound 4, half-maximal inhibitory concentration: > 100000 nM
Compound 4: no number, only a limit; the forecaster's own chance of this, stated with the estimate: 75%; the middle value lies beyond the limit too.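

Placing (4-nitrophenyl)sulfonyl on the amine nitrogen in the ring in place of 3-methylbenzyl gives an at least 3.6-fold higher number from compound 1 to compound 4 (0.56 log units; beyond the scatter) in this assay, the same direction as the (2,4,6-trimethylphenyl)sulfonyl group of compound 3. The weak result at this position therefore holds for two sulfonyl groups with differently substituted aromatic rings, not just one. The steps among compound 2, compound 3 and compound 4 cannot be read, so these groups cannot be ranked against one another, and only compound 1 has a number: the limit of > 100000 nM in this assay, at which 3 of the 4 values shown sit.

On these data alone, how far compound 2, compound 3 and compound 4 lie past the limit remains open. Also open, as far as these compounds go, is whether an acetyl group or an unsubstituted benzyl on this nitrogen would give a measurable value.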